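The source may hold more compounds than are shown below. What is called first, only, known or untested is meant among the compounds shown, and "the series" means these compounds.

Measured so far in a functional assay on L1210 cells (Mus musculus) for antiproliferative activity; on this read-out higher numbers stand for higher potency (the scale is a negative logarithm) and lower numbers for lower potency:
compound 1 `CN(Cc1ccccc1)/N=N/c1nc[nH]c1C(N)=O` gives 3.43;
compound 2 `C=CCN(C)/N=N/c1ccc(C(N)=O)cc1` gives 3.38;
compound 3 `CCCCCN(C)/N=N/c1nc[nH]c1C(N)=O` gives 3.58.

Compound 3 stands at the upper end of these three numbers, yet none of the gaps between them exceeds the usual scatter. Going by the values given here, the only single-point change among the measured compounds is a number 0.15 log units higher from compound 1 to compound 3 (within the scatter), butyl in place of phenyl on a saturated chain carbon bound to an amine nitrogen, and the numbers of compound 2 and compound 3 lie as close together as repeated measurements of this kind commonly do. The three compounds therefore read as a flat set.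

Compound 4 `CN(/N=N/c1nc[nH]c1C(N)=O)c1cccs1` has not yet been measured. It differs from compound 3 in one place: thiophen-2-yl in place of pentyl on an amine nitrogen. Among the compounds with values here, the only measured step that bears on this is the exchange of phenyl for butyl on a chain carbon next to the amine nitrogen, which moved the number within the scatter. That precedent concerns a ring on a chain carbon, not a ring set directly on the amine nitrogen, so it is a loose guide. Nothing in the measured set separates a ring from a chain by more than the scatter, so no step beyond the scatter is expected in this assay. Compound 4 is estimated at 3.5, between 3.1 and 3.9. The expected step of a number 0.08 log units lower from compound 3 to compound 4 (within the scatter) is thus small and within the scatter.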

Compound 4, logarithm of the reciprocal of the active concentration, log(1/C): 3.87
For compound 4 the middle estimate is 0.37 log units below the measured one, and the stated range covers the measured number.
By their numbers in this assay, from the lowest: compounds 2, 1, 3 and 4 (each within the scatter of the next, the first and the last beyond it).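

Set directly on the amine nitrogen, whose other neighbours are the double-bonded nitrogen and a saturated chain carbon, an aromatic ring can stand in place of a chain: in this assay the exchange of pentyl for thiophen-2-yl gives a number 0.29 log units higher from compound 3 to compound 4 (within the scatter). Going by these compounds alone, the earlier compounds offered only chains on this nitrogen or a phenyl ring carried on a saturated chain carbon, so this is the first direct reading of a ring at the position, and it brings in a five-membered aromatic ring with a sulfur atom and a hydrogen-bond acceptor while the heavy-atom count stays the same, without a step beyond the scatter. No measurement in hand accounts for this reading, which therefore stands as an observation only.

With a single ring at this position, the compounds shown leave open whether another one, such as furan-2-yl or a pyridine ring, would read the same in this assay, or whether a chain ending in a carboxylic acid or an amine would produce a step beyond the scatter. They also leave open whether thiophen-2-yl would behave the same way on the core of compound 2, which differs from the core of compound 3 and compound 4.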